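Methylating a Phenol in a Lactone Series: Expected Effect

The source may hold more compounds than are shown below. What is called first, only, known or untested is meant among the compounds shown, and "the series" means these compounds.

Of the compounds shown here, three have been measured in a functional assay on HaCaT cells (Homo sapiens) for inhibition, read by sulforhodamine B assay, with a stated time of 48 h; on this read-out lower numbers stand for stronger inhibition of growth and higher numbers for weaker inhibition of growth. Compound 1 `COc1ccc(/C=C/C2(C)C=CC(=O)O2)c(OC)c1OC` gives 217000 nM; compound 2 `COc1c(O)ccc(/C=C/C2(C)C=CC(=O)O2)c1OC` gives 64400 nM; compound 3 `CC1(/C=C/c2ccccc2O)C=CC(=O)O1` gives 57300 nM. The difference between the cores of compound 2 and compound 3 is not broken down here. Between compound 2 and compound 1 the change is methyl in place of hydrogen on an oxygen on an aromatic ring, and it produced a 3.4-fold higher number from compound 2 to compound 1 (0.53 log units; beyond the scatter). Compound 4 `COc1ccccc1/C=C/C1(C)C=CC(=O)O1` is not yet measured; it differs from compound 3 by methyl in place of hydrogen on an oxygen on an aromatic ring, the same change at the same kind of place. Going by the values given here, for compound 4 a step of a 3.0-fold higher number from compound 3 to compound 4 (0.47 log units; beyond the scatter) is expected in this assay, because a 3.4-fold higher number from compound 2 to compound 1 (0.53 log units; beyond the scatter) is the only example of this change so far. Compound 4 is therefore estimated at 170000 nM, in the range 70000 nM to 400000 nM.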

Compound 4, concentration for total growth inhibition: 30800 nM
Estimate against measurement, compound 4: 5.5-fold (0.74 log units) above; the measured number lies below the stated range.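

Putting methoxy in place of hydroxy did not act the same way on the two cores in this assay: the same change on two cores in this assay, a 3.4-fold higher number (0.53 log units; beyond the scatter) from compound 2 to compound 1 and a 1.9-fold lower number (0.27 log units; within the scatter) from compound 3 to compound 4, 6.3-fold (0.80 log units) apart, beyond the scatter of two such steps

The new step is a 1.9-fold lower number from compound 3 to compound 4 (0.27 log units; within the scatter) and leaves the two compounds indistinguishable, whereas the earlier step weakened growth inhibition on its core. With a single pair on each core, this shows that the result from one core cannot be relied on to predict the other, but it does not show why they differ or what a further core would do.

Still open, from the compounds shown here alone, is how an ethyl group on the same oxygen would read on either core. Going by these compounds, an amine in place of the hydroxy group is equally open.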